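The source may hold more compounds than are shown below. What is called first, only, known or untested is meant among the compounds shown, and "the series" means these compounds.

Measured compounds:
- compound 1, `CCCCCCCc1c(C)nc2ccccc2c1O`: 5100 nM
- compound 2, `C=C(CCCCCCC)c1c(C)[nH]c2ccccc2c1=O`: 89100 nM
- compound 3, `CCCCCCCc1c(C)[nH]c2cc(OC)c(Cl)cc2c1=O`: > 37100 nM

Within the data shown here, in an ADME assay on J774 cells (Mus musculus) for cytotoxicity (on this read-out higher numbers stand for an effect only at larger amounts of compound and lower numbers for an effect already at smaller amounts), compound 1 gives 5100 nM and compound 2 gives 89100 nM; no step is drawn between them, the two values simply stand as they are. For compound 3 the read-out of this assay is a limit, not a number: > 37100 nM, so compound 3 stands at the upper edge of what is shown, where (the limit of > 37100 nM in this assay, at which 1 of the 3 values shown sits).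

Compound 4, `C=C(CCCCC)c1c(C)[nH]c2cc(OC)c(Cl)cc2c1=O`, is not yet measured in this assay. It differs from compound 3 in one place: a group of 7 heavy atoms (7 carbon; no ring) in place of a group of 7 heavy atoms (7 carbon; no ring), on an aromatic carbon. The heptyl leaves and a group of 7 heavy atoms (7 carbon; no ring) with 1 double bond outside aromatic rings enters, on an aromatic carbon ortho to a methyl group.

With compound 3 at a limit, the step from compound 3 to compound 4 is expected to stay within the scatter, a step that the limit leaves unreadable from compound 3 to compound 4, with a fair chance that compound 4 again returns only a limit. For compound 4 the estimate in this assay is 50000 nM, with a range from 20000 nM to 150000 nM.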

Compound 4, half-maximal effective concentration: 18900 nM
Compound 4: the middle estimate sits 2.6-fold (0.42 log units) above what was measured, outside the stated range (below it).
By their numbers in this assay, from the lowest: compound 1; then compound 4; then compound 2.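

In this assay, replacing the heptyl on this aromatic carbon with the group of 7 heavy atoms carrying 1 double bond gives an at least 1.9-fold lower number from compound 3 to compound 4 (0.29 log units; that floor lies within the scatter). Among these compounds, this is the first comparison between compounds that differ in one place, and it shows that on the core of compound 3 the new group yields a measured number where the heptyl yields only a limit. The full size of the step cannot be read, only its floor: the limit of > 37100 nM in this assay, at which 1 of the 4 values shown sits.

The compounds shown leave open whether the same exchange would move the read-out on a core without the chlorine and methoxy groups. They also leave open how a chain ending in an amine or a carboxylic acid would read at this aromatic carbon.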